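One More Methyl on the Chain: Compound 1 to Compound 3

The source may hold more compounds than are shown below. What is called first, only, known or untested is meant among the compounds shown, and "the series" means these compounds.

compound 1 `CCCCCCCNc1cnc(C(=O)NCc2ccccc2)cn1` — an ADME assay on HEL cells (Homo sapiens) for cytotoxicity, read by microscopy, with a stated time of 6 days; a lower number here means that less compound is tolerated, a higher number that more compound is tolerated: > 100000 nM, a limit of the assay rather than a number.
compound 2 `CCCCCCNc1cncc(C(=O)NCc2ccccc2)n1` — this assay : > 100000 nM, likewise a limit.

For the measured compounds named here, compound 1 therefore stands at no measured number in this assay; the only other value shown is a limit as well, which is the limit of > 100000 nM in this assay, at which 2 of the 2 values shown sit. Compound 3 `CCCCCCCCNc1cnc(C(=O)NCc2ccccc2)cn1` differs from compound 1 by methyl in place of hydrogen on a saturated chain carbon, seven bonds along the chain from a nitrogen on an aromatic ring. Going by the values given here, no measured step between compounds exists here, so the expectation rests on the fact that both values shown sit at the limit. The step of a number no higher from compound 1 to compound 3 (the limit leaves the size open) is expected to be none beyond the scatter. Compound 3 is thus expected at 100000 nM, between 50000 nM and 200000 nM, most likely reported again as a limit.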

Compound 3, minimum cytotoxic concentration: 100000 nM
Compound 3: middle estimate and measured number agree at the digits printed; low and high end bracket the measured number.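

In this assay, methyl in place of hydrogen on a saturated chain carbon, seven bonds along the chain from a nitrogen on an aromatic ring, gives a number no higher from compound 1 to compound 3 (the limit leaves the size open). Compound 3 is the only compound shown with a plain number, 100000 nM, rather than a limit. Even so, this position is still read close to the assay's limit, so the real size of the change stays hidden: the limit of > 100000 nM in this assay, at which 2 of the 3 values shown sit.

The compounds shown leave open whether a longer chain would bring a clearly lower number in this assay. They also leave open what an amine or a carboxylic acid at the chain end would do.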